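The source may report more compounds than this note shows. Statements on the series, on what has been measured and on what is new or still open speak of the compounds shown alone.

Compound 1, `COc1cc(-n2cnc3ccc(-c4ccc([N+](=O)[O-])cc4)cc32)cc(OC)c1OC`, is the starting point. In a functional assay on A549 cells (Homo sapiens) for antiproliferative activity, read by MTT assay, with a stated time of 72 h (a higher number here means a weaker inhibitor, a lower number a stronger inhibitor), compound 1 gives 8940 nM. Compound 2, `COc1cc(-c2ccc3ncn(-c4cc(OC)c(OC)c(OC)c4)c3c2)cc(OC)c1OC`, was tested alongside it. In this assay compound 2 gives > 10000 nM, which is a limit of the assay rather than a number. Among the compounds with values here, compound 1 therefore holds the only measured number here, while the other value is the limit of > 10000 nM in this assay, at which 1 of the 2 values shown sits. Compound 3, `COc1cc(-n2cnc3ccc(-c4ccc(Cl)cc4)cc32)cc(OC)c1OC`, has not yet been measured. It differs from compound 1 by chloro in place of nitro on an aromatic carbon. Within the data shown here, no step between two measured compounds is available, so the size of such a change in this assay cannot be read from any matching pair. Compound 3 is expected to land close to compound 1, with an estimated step of a 1.3-fold higher number from compound 1 to compound 3 (0.13 log units; within the scatter) that could well stay within the scatter. The estimate for compound 3 in this assay is 12000 nM, with a range from 4000 nM to 40000 nM.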

Compound 3, half-maximal inhibitory concentration: > 10000 nM
Compound 3: a limit, no number; the forecaster's own chance of this, stated with the estimate: 50%; the middle value is on the limit's open side.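

In this assay, the value of compound 3 is a limit of the assay and not a number, so chloro in place of nitro, on an aromatic carbon para to a large group, can be read only as a floor: an at least 1.1-fold higher number from compound 1 to compound 3 (0.04 log units; that floor lies within the scatter). Within the data shown here, this is the first step that can be read at this position, and it shows that chloro brings no lower number than nitro. Little of this end of the read-out yields real numbers: the limit of > 10000 nM in this assay, at which 2 of the 3 values shown sit.

From the compounds shown here alone, the true size of the step stays open, and it could be small or large. Also open, going by these compounds, is whether an amine or a carboxylic acid on the same carbon would bring the number clearly below that of compound 1.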